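Propyl to benzyl ester on a furan-bearing core

The source may hold more compounds than are shown below. What is called first, only, known or untested is meant among the compounds shown, and "the series" means these compounds.

Measured so far:
- compound 1 `CCCOC(=O)C1=C(C)N(C)C(=O)NC1c1ccco1` — 8%
- compound 2 `CCCOC(=O)C1=C(C)N(C)C(=O)NC1c1ccoc1` — 16%

In an assay on membranes from HeLa cells for displacement of a labelled ligand from adenosine receptor A3 (Homo sapiens), read by scintillation counting, with a stated time of 180 min, tested at 1 uM (a higher number here means more inhibition at the concentration tested (going by the name of the read-out), a lower number less inhibition), compound 1 gives 8% and compound 2 gives 16%. The two differ only in the furan attachment, and the step of a number 8 percentage points higher from compound 1 to compound 2 (within the scatter) lies within the scatter, so compound 2 and compound 1 cannot be told apart on these numbers; both show little displacement at the tested concentration.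

Compound 3 `CC1=C(C(=O)OCc2ccccc2)C(c2ccoc2)NC(=O)N1C` has not yet been measured. It differs from compound 2 by phenyl in place of ethyl on a saturated chain carbon bound to an oxygen next to a carbonyl group. No measured pair tests this kind of change at the ester, so nothing among the shown steps bears on it directly; the only shown step concerns the furan and was within the scatter.

Without a relevant precedent, compound 3 is expected to stay close to compound 2, a step of no change at the digits printed from compound 2 to compound 3 (within the scatter) in this assay, with an estimate of 16% and a range from 2% to 38%.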

Compound 3, a percentage reported as inhibition, at one concentration (the size of the read-out at that concentration, not a potency): 25%
Compound 3: middle estimate off by 9 percentage points, on the low side; the range from low to high includes it.
By their numbers in this assay, from the lowest: compounds 1, 2 and 3 (each within the scatter of the next, the first and the last beyond it).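

For the compounds shown here, this is the first test of the ester end of the molecule: a bulkier group, phenyl with its six-membered aromatic ring of carbon, replaces ethyl, and the result is a number 9 percentage points higher from compound 2 to compound 3 (within the scatter) in this assay. The ester position therefore takes this much larger group with no loss that the assay can detect, and with no gain that can be separated from the scatter. No measurement shown here offers an explanation for the result.

As far as these compounds go, it remains open whether the same ester change would give a similar result with furan-2-yl in place of furan-3-yl. From the compounds shown here alone, it is also open whether a longer chain at the ester, or an amine or a carboxylic acid on the phenyl ring, would shift the number beyond the scatter.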